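Swapping a halogenated nitrile ring for a nitrophenyl group

The source may report more compounds than this note shows. Statements on the series, on what has been measured and on what is new or still open speak of the compounds shown alone.

Of the compounds shown here, two built on a shared core have been measured in a physicochemical assay for lipophilicity, measured as octanol-water partition; on this read-out higher numbers stand for higher lipophilicity and lower numbers for lower lipophilicity. Compound 1 `C/C(=N\NC(=O)COc1cccc2ccccc12)c1ccc(C#N)cc1Br` gives 3.61 in this assay, and compound 2 `O=C(COc1cccc2ccccc12)N/N=C/c1c(O)ccc2ccccc12` gives 4.74. Compound 1 thus holds the lower of the two numbers, and the value of compound 2 sits higher by a margin beyond the scatter of repeated measurements. Among the measured compounds shown here, since the two structures differ in more than one place, no single step between them is drawn.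

Compound 3 `C/C(=N\NC(=O)COc1cccc2ccccc12)c1ccc([N+](=O)[O-])cc1` has not yet been measured in this assay. Its structure departs from compound 1 in one place: 4-nitrophenyl in place of 2-bromo-4-cyanophenyl on a carbon with a double bond to nitrogen. The group that leaves carries a bromine and a nitrile; the group that enters carries a nitro group with two hydrogen-bond acceptors in place of one. For the measured compounds named here, no measured pair shows what this exchange does, so the expectation rests on the change itself rather than on a recorded step. A moderate fall in this assay is expected, amounting to an estimated a number 0.56 log units lower from compound 1 to compound 3 (beyond the scatter). Compound 3 is therefore expected to give about 3.05, with a plausible range from 2.6 to 3.5.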

Compound 3, partition coefficient: 3.37
The estimate for compound 3 lay 0.32 log units below the measured number, within the range that was stated.
By their numbers in this assay, from the lowest: compounds 3 and 1 (each within the scatter of the next); then compound 2.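

In this assay, among the compounds shown here, putting 4-nitrophenyl in place of 2-bromo-4-cyanophenyl on the carbon with a double bond to nitrogen gives a number 0.24 log units lower from compound 1 to compound 3 (within the scatter) and so supplies the first recorded step at this place. On this read-out, compound 1 and compound 3 cannot be told apart, so a ring carrying a bromine and a nitrile and a ring carrying a nitro group read alike in this one pair, even though the two groups differ in their atoms and in their counted hydrogen-bond acceptors. Nothing measured here explains why the two numbers fall so close together.

The compounds shown leave open what the bromine, the nitrile and the nitro group each contribute alone, as this single step removes the first two and brings in the third at the same time. They also leave open whether a ring carrying an amine or a carboxylic acid at this place, or a plain phenyl ring, would shift the number in this assay by more than the scatter of repeated measurements.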